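This account rests on a few compounds, and the source may have more. Where it says the series, first, only, none or still open, it means among the compounds named here.

Working notes on the series.

Of the compounds shown here, three sharing one core have been measured in an assay on isolated protein for displacement of a labelled ligand from metabotropic glutamate receptor 5 (Homo sapiens), with a stated time of 60 min, tested at 1 uM; on this read-out lower numbers stand for less inhibition and higher numbers for more inhibition at the one concentration tested (going by the name of the read-out). Compound 1 `COc1ccc(S(=O)(=O)c2cnc3ccc(C)cc3c2N2CCC(C)CC2)cc1` gives 62%. Compound 2 `Cc1ccc2ncc(S(=O)(=O)c3ccc(Cl)c(Cl)c3)c(N3CCC(C)CC3)c2c1` gives 82%. Compound 3 `COc1ccc(S(=O)(=O)c2cnc3ccc(F)cc3c2N2CCC(C)CC2)cc1` gives 85%; its number lies within the scatter of compound 2 and beyond it only against compound 1.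

Two single-point changes link these. From compound 1 to compound 2 the change is 3,4-dichlorophenyl in place of 4-methoxyphenyl on a sulfonyl sulfur, and the step is a number 20 percentage points higher from compound 1 to compound 2 (beyond the scatter). From compound 1 to compound 3 the change is fluoro in place of methyl on an aromatic carbon, with a step of a number 23 percentage points higher from compound 1 to compound 3 (beyond the scatter).

Compound 4 `CC1CCN(c2c(S(=O)(=O)c3ccc(Cl)c(Cl)c3)cnc3ccc(F)cc23)CC1` is not yet measured. It differs from compound 3 by 3,4-dichlorophenyl in place of 4-methoxyphenyl on a sulfonyl sulfur, the same change as from compound 1 to compound 2, since the two place descriptions agree word for word. The cores of compound 1 and compound 3 differ as described by fluoro in place of methyl on an aromatic carbon.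

For compound 4 in this assay the step from compound 3 is expected to be a number 8 percentage points higher from compound 3 to compound 4 (within the scatter), smaller than the earlier step because compound 3 already gives 85%, a number that leaves little room for a higher one. Compound 4 is therefore estimated at 93%, between 83% and 99%.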

Compound 4, a percentage reported as inhibition, at one concentration (the size of the read-out at that concentration, not a potency): 91%
Estimate against measurement, compound 4: 2 percentage points above; the measured number falls inside the stated range.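

In this assay, the sulfonyl change on the core of compound 3 gives a number 6 percentage points higher from compound 3 to compound 4 (within the scatter), and the fluoro change with 3,4-dichlorophenyl on the sulfonyl sulfur gives a number 9 percentage points higher from compound 2 to compound 4 (within the scatter). The replacement of 4-methoxyphenyl by 3,4-dichlorophenyl is not shown to behave differently on the two cores: the same change on two cores in this assay, a number 20 percentage points higher (beyond the scatter) from compound 1 to compound 2 and a number 6 percentage points higher (within the scatter) from compound 3 to compound 4, 14 percentage points apart, within the scatter of two such steps. The same holds for fluoro in place of methyl, but both new steps lie within the scatter, so neither change is shown to bring a real gain on its second core, and a reading at one concentration gives no potency: the same change on two cores in this assay, a number 23 percentage points higher (beyond the scatter) from compound 1 to compound 3 and a number 9 percentage points higher (within the scatter) from compound 2 to compound 4, 14 percentage points apart, within the scatter of two such steps.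

The compounds shown leave open how a nitrile or a trifluoromethyl would read in place of fluoro on the aromatic carbon. Also open, going by these compounds, is whether an amine or a carboxylic acid on the aromatic ring attached to the sulfonyl sulfur would fit the same pattern of steps.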